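Notes on a fluoro addition in the sulfonyl triazole series

This account rests on a few compounds, and the source may have more. Where it says the series, first, only, none or still open, it means among the compounds named here.

Measured compounds, intrinsic clearance in human liver microsomes:
compound 1 `CC(C)COc1ncc(-c2cc(F)c(-c3nnc(S(=O)(=O)CC4CC4)[nH]3)cc2F)cc1Cl` — 67 uL/min
compound 2 `CC(C)COc1ncc(-c2ccc(-c3nnc(S(=O)(=O)C4CCC4)[nH]3)cc2F)cc1Cl` — 93 uL/min
compound 3 `COc1cc(-c2nnc(S(=O)(=O)C3CCC3)[nH]2)ccc1-c1cnc(OCC(C)C)c(Cl)c1` — 59 uL/min

In an ADME assay on microsomes from liver (Homo sapiens) for metabolic stability (on this read-out higher numbers stand for fast clearance and lower numbers for slow clearance), compound 3 has the lowest of the three numbers, but its gaps to compound 1 and compound 2 are both within the scatter. For the measured compounds named here, the one single-place step available, a 1.6-fold lower number from compound 2 to compound 3 (0.20 log units; within the scatter), was also within the scatter. Compound 4 `COc1cc(-c2nnc(S(=O)(=O)C3CCC3)[nH]2)c(F)cc1-c1cnc(OCC(C)C)c(Cl)c1` differs from compound 3 in one place: fluoro in place of hydrogen on an aromatic carbon. Going by the values given here, no measured step matches this change. Compound 1 gives 67 uL/min and compound 2 gives 93 uL/min; these two differ in more than one place and show only a gap within the scatter. The step from compound 3 to compound 4 is therefore expected to be a 1.1-fold lower number from compound 3 to compound 4 (0.03 log units; within the scatter), no change beyond the scatter. Compound 4 is estimated at 55 uL/min, with a range from 28 uL/min to 110 uL/min.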

Compound 4, intrinsic clearance in a liver preparation (reported as CLH), per the amount of preparation that the assay uses: 16 uL/min
For compound 4 the middle estimate is 3.4-fold (0.54 log units) above the measured one; the whole stated range lies above it.
By their numbers in this assay, from the lowest: compound 4; then compounds 3, 1 and 2 (each within the scatter of the next).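

In this assay, fluoro in place of hydrogen on an aromatic carbon, para to a methoxy group, gives a 3.7-fold lower number from compound 3 to compound 4 (0.57 log units; beyond the scatter). For the compounds shown here, this is the first single-place change to move the number beyond the scatter, and it does so with one added heavy atom at a position ortho to a large group and meta to a large group. Nothing available explains the step.

As far as these compounds go, whether an amine or a nitrile at this position would give a similar step stays open. One step also cannot show whether fluoro here behaves the same with other sulfonyl groups.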